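The source may hold more compounds than are shown below. What is called first, only, known or untested is meant among the compounds shown, and "the series" means these compounds.

Working notes on the series. Compound 1 `Cc1ccc(-c2cc(C(=O)N[C@H](C)c3ccc(C(F)(F)F)[n+]([O-])c3)cc(C(C)(C)O)c2)nc1` is measured in an ADME assay on a cell-free system (plasma, Rattus norvegicus) for protein binding, at 62.4%, the highest unbound fraction among the three measured compounds. Compound 2 `Cc1ccc(-c2cc(C(=O)N[C@H](C)c3ccc(C(F)(F)F)nc3)cc(C(C)(C)O)c2)nc1` gives 95.2% in this assay, and compound 3 `Cc1ccc(-c2cc(C(=O)N[C@H](C)c3ccc(C(F)(F)F)[n+]([O-])c3)cc(-c3ncccc3F)c2)nc1` gives 95.2%. The two measured steps from compound 1 are a 7.8-fold lower unbound fraction from compound 1 to compound 2 (0.89 log units; beyond the scatter) and a 7.8-fold lower unbound fraction from compound 1 to compound 3 (0.89 log units; beyond the scatter), so both changes made so far from compound 1 lowered the unbound fraction by a similar amount.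

Compound 4 `C[C@@H](NC(=O)c1cc(-c2ccc(Cl)cn2)cc(C(C)(C)O)c1)c1ccc(C(F)(F)F)[n+]([O-])c1` differs from compound 1 in one place: chloro in place of methyl on an aromatic carbon. Neither measured step concerns the same place: one concerns the group on the saturated chain carbon bound to the amide-type nitrogen, the other the 1-hydroxy-1-methylethyl group on an aromatic carbon. Among the compounds with values here, they set no direct precedent for exchanging chloro for methyl on the 5-methylpyridin-2-yl ring. Given that both known changes from compound 1 raised binding, a shift in the same direction, smaller than either measured step and possibly within the scatter, is expected here. Compound 4 is expected to give 75% in this assay, with a range of 58% to 88%. This corresponds to an expected step of a 1.5-fold lower unbound fraction from compound 1 to compound 4 (0.18 log units; within the scatter).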

Compound 4, plasma protein binding: 76.2%
Compound 4: middle estimate off by 1.1-fold (0.02 log units) (unbound fraction), on the high side; low and high end bracket the measured number.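

In this assay, 5-chloropyridin-2-yl in place of 5-methylpyridin-2-yl gives a 1.6-fold lower unbound fraction from compound 1 to compound 4 (0.20 log units; within the scatter), so at this position, two atoms from the ring nitrogen, chloro and methyl cannot be told apart on this read-out. This place of compound 1 therefore behaves differently from the two places changed earlier, whose steps both lie beyond the scatter, and this exchange keeps the unbound fraction of compound 1 within that scatter. No supporting measurement bears on this result.

The compounds shown leave open whether a larger or different group at this position, such as an amine, a methoxy group or a nitrile, would also stay within the scatter of compound 1. They also leave open whether the same exchange would read alike on the cores of compound 2 and compound 3.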